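Adding a methyl to compound 1's ring nitrogen

The source may hold more compounds than are shown below. What is called first, only, known or untested is meant among the compounds shown, and "the series" means these compounds.

Measured so far:
- compound 1 (`CC(C)C(/C=C1\NC(=O)NC1=O)c1ccc(-c2ccc3cccc(F)c3c2)[nH]c1=O`) gives 12.3 10^-6 cm/s in an ADME assay on MDCK cells (Canis lupus familiaris) for permeability, in the apical to basolateral direction; a lower number here means that the compound crosses the layer more slowly, a higher number that the compound crosses the layer faster
- compound 2 (`CC(C)/C(=C1/SC(=O)NC1=O)c1ccc(-c2ccc3cccc(F)c3c2)[nH]c1=O`) gives 22.9 10^-6 cm/s in this assay

Two numbers make a very short scale. Compound 1 gives 12.3 10^-6 cm/s and sits within the usual scatter of compound 2, so repeated measurements could not be expected to put these two compounds in a firm order. They differ in more than one place, so their values offer no clean lesson about any single structural change.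

Compound 3 (`CC(C)C(/C=C1/C(=O)NC(=O)N1C)c1ccc(-c2ccc3cccc(F)c3c2)[nH]c1=O`) has not yet been measured. It keeps the core of compound 1 and makes one change: methyl in place of hydrogen on an amide-type nitrogen in a ring. For the measured compounds named here, no measured pair shows this change, so the size of the step must be judged with little support. In this assay a small upward step is expected, one that may not clear the scatter. The expected change is a 1.3-fold higher number from compound 1 to compound 3 (0.11 log units; within the scatter) in this estimate. The estimated value for compound 3 is 16 10^-6 cm/s (expected range 8 10^-6 cm/s to 32 10^-6 cm/s).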

Compound 3, apparent permeability: 14.1 10^-6 cm/s
Estimate against measurement, compound 3: 1.1-fold (0.05 log units) above; low and high end bracket the measured number.
By their numbers in this assay, from the lowest: compounds 1, 3 and 2 (each within the scatter of the next).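

Swapping the hydrogen on the amide-type nitrogen in the ring for methyl gives a 1.1-fold higher number from compound 1 to compound 3 (0.06 log units; within the scatter) in this assay, the first reading of a single structural change in this set, since compound 1 and compound 2 differ in more than one place. The step lies within the scatter, so at this ring nitrogen the hydrogen can give way to a methyl without a shift that repeated measurements could be expected to tell apart, and one added carbon on this atom leaves the number where the scatter already allows it to be. No measurement here offers an explanation for a step of this size.

One methyl cannot show how far this tolerance runs: an ethyl, a longer chain or a carboxylic acid on the same nitrogen might give a step beyond the scatter or might not. On these data alone, whether methyl would give a similar step on the core of compound 2 also remains open, as that core carries a different ring.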